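Trimming a Benzylic Amine Side Chain to a Hydroxyl

The compounds below may be only part of what the source reports. "The series", "measured", "known", "first", "only" and "open" are said of these compounds alone.

Three stilbenes sharing one core have been tested in a functional assay on HepG2 cells (Homo sapiens) for antiproliferative activity, read by CCK-8 assay, with a stated time of 48 h; a lower number here means a stronger inhibitor, a higher number a weaker inhibitor. Compound 3 `COc1ccc(/C=C\c2cc(OC)c(OC)c(OC)c2)cc1OCc1ccc(CNCCN(C)C)cc1` gives 4400 nM and stands with the highest number of the three. Its nearest neighbour is compound 1 `COc1ccc(/C=C\c2cc(OC)c(OC)c(OC)c2)cc1OCc1ccc(CN2CC[C@@H](C(=O)O)C2)cc1`, which gives 2300 nM, and the step of a 1.9-fold higher number from compound 1 to compound 3 (0.28 log units; within the scatter) stays within the scatter. Compound 2 `COc1ccc(/C=C\c2cc(OC)c(OC)c(OC)c2)cc1OCc1ccc(C=O)cc1` gives 800 nM, and the step of a 5.5-fold higher number from compound 2 to compound 3 (0.74 log units; beyond the scatter) is a modest one beyond the scatter; the step of a 2.9-fold lower number from compound 1 to compound 2 (0.46 log units; beyond the scatter) also reaches beyond the scatter.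

Compound 4 `COc1ccc(/C=C\c2cc(OC)c(OC)c(OC)c2)cc1OCc1ccc(CO)cc1` is now to be measured. It differs from compound 3 by hydroxy in place of (2-(dimethylamino)ethyl)amino on a saturated chain carbon bound to an aromatic carbon. Among the compounds with values here, the step that bears most on it is the one from compound 2 to compound 3, since compound 2 also carries a single heavy atom at the same place, and there the formyl group was the more active partner. Within the data shown here, the change to compound 4 removes the same six-atom chain, so a step of similar size in the opposite direction is expected, with the reservation that only one small group, that of compound 2, has been measured here.

Compound 4 is therefore expected to show a 3.7-fold lower number from compound 3 to compound 4 (0.56 log units; beyond the scatter) in this assay. The estimate for compound 4 is 1200 nM, with a range from 400 nM to 3500 nM.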

Compound 4, half-maximal inhibitory concentration: 2400 nM
Compound 4: the middle estimate sits 2.0-fold (0.30 log units) below what was measured; the range from low to high includes it.
By their numbers in this assay, from the lowest: compound 2; then compounds 1, 4 and 3 (each within the scatter of the next).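

At this saturated chain carbon bound to an aromatic carbon, cutting the substituent down to hydroxy does not bring the number to the level of compound 2 in this assay. The step to the small group stays within the scatter (a 1.8-fold lower number from compound 3 to compound 4 (0.26 log units; within the scatter)), as does the step from the 3-carboxypyrrolidin-1-yl compound (a 1.0-fold higher number from compound 1 to compound 4 (0.02 log units; within the scatter)), so these three side chains cannot be told apart here, even though the (2-(dimethylamino)ethyl)amino group has six heavy atoms and hydroxy has one. A single heavy atom at this place is therefore not what marks out compound 2, since the exchange of formyl for hydroxymethyl is itself a modest step beyond the scatter (a 3.0-fold higher number from compound 2 to compound 4 (0.48 log units; beyond the scatter)), and nothing available gives a reason for that gap.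

From the compounds shown here alone, whether formyl stands alone among small groups on this aromatic carbon remains open, and a carboxylic acid, a methyl ester or a primary aminomethyl group there would test it. Going by these compounds, it is also open whether a longer chain ending in hydroxy would stay level with compound 4 or move away from it.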